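The compounds below may be only part of what the source reports. "The series", "measured", "known", "first", "only" and "open" are said of these compounds alone.

In an ADME assay on HeLa cells (Homo sapiens) for cytotoxicity, read by MTT assay (on this read-out higher numbers stand for weaker inhibition and lower numbers for stronger inhibition), compound 3 `COc1ccc(C[C@H]2COC(=O)[C@@H]2Cc2ccc(OCC(=O)N3CCCC3)c(OC)c2)cc1OC` is reported only as a limit, >= 600000 nM. Compound 2 `COc1ccc(C[C@H]2COC(=O)[C@@H]2Cc2ccc(OCC(=O)Nc3ccc(C)cc3)c(OC)c2)cc1OC` gives 228000 nM, and compound 1 `COC(=O)[C@@H]1CCCN1C(=O)CCC(=O)Oc1ccc(C[C@H]2C(=O)OC[C@@H]2Cc2ccc(OC)c(OC)c2)cc1OC` gives 145000 nM. For the measured compounds named here, the single measured step is an at least 2.6-fold higher number from compound 2 to compound 3 (0.42 log units; beyond the scatter), and it concerns only the group on the carbonyl carbon. Moving on to compound 4 `COc1ccc(C[C@H]2COC(=O)[C@@H]2Cc2ccc(OC(=O)CCC(=O)N3CCCCC3)c(OC)c2)cc1OC`, the change is a group of 12 heavy atoms (9 carbon, 1 nitrogen, 2 oxygen; one six-membered non-aromatic ring with 1 hetero atom) in place of a group of 8 heavy atoms (6 carbon, 1 nitrogen, 1 oxygen; one five-membered non-aromatic ring with 1 hetero atom), on an oxygen on an aromatic ring. Going by the values given here, no measured step matches this change, so the measured step offers only a rough guide to size. The closest reference for the entering group is compound 1, at 145000 nM, which points to a lower number in this assay. A modest step is therefore expected, an at least 2.1-fold lower number from compound 3 to compound 4 (0.33 log units; beyond the scatter). For compound 4 the estimate is 280000 nM, with an expected range of 110000 nM to 600000 nM.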

Compound 4, half-maximal inhibitory concentration: 128000 nM
The estimate for compound 4 lay 2.2-fold (0.34 log units) above the measured number; the range from low to high includes it.
By their numbers in this assay, from the lowest: compounds 4, 1 and 2 (each within the scatter of the next). At a limit, above all of these: compound 3.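

For the compounds shown here, on the oxygen on the aromatic ring, the entering group gives an at least 4.6-fold lower number from compound 3 to compound 4 (0.67 log units; beyond the scatter), the first step of at least modest size at this place. The other two comparisons stay within the scatter, with a 1.8-fold lower number from compound 2 to compound 4 (0.25 log units; within the scatter) and, for piperidin-1-yl on the carbonyl carbon, a 1.1-fold lower number from compound 1 to compound 4 (0.05 log units; within the scatter). Compound 3 is recorded only as a limit: the limit of >= 600000 nM in this assay, at which 1 of the 4 values shown sits.

The step from compound 3 to compound 4 changes both the ring and the chain, and the compounds shown do not separate the two. As far as these compounds go, a carboxylic acid or an amine at the end of the chain also remains open.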